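Removing a Chloro Group from the Least Soluble Amide

The source may hold more compounds than are shown below. What is called first, only, known or untested is meant among the compounds shown, and "the series" means these compounds.

Measured compounds:
Compound 1, `O=C(Nc1cc(-c2nc3ccccc3s2)ccc1Cl)c1cc([N+](=O)[O-])ccc1Cl`: 100 nM
Compound 2, `Cc1ccc(-c2nc3ccccc3o2)cc1NC(=O)c1cc([N+](=O)[O-])ccc1Cl`: 310 nM
Compound 3, `O=C(Nc1nc(-c2cccc(F)c2)cs1)c1cc([N+](=O)[O-])ccc1Cl`: 780 nM

In a physicochemical assay for solubility, read by spectrophotometry, in phosphate buffer, measured as kinetic solubility, with a stated time of 18 h, at pH 7.4 (a lower number here means a less soluble compound, a higher number a more soluble compound), compound 1 stands lowest of the three numbers shown. Compound 2 lies above it, beyond the usual scatter, and compound 3 lies higher still, also beyond the scatter. Compound 4, `O=C(Nc1cccc(-c2nc3ccccc3s2)c1)c1cc([N+](=O)[O-])ccc1Cl`, has not yet been measured. It differs from compound 1 in one place: hydrogen in place of chloro on an aromatic carbon. The change sits on an aromatic carbon of a six-membered aromatic ring of carbon only, ortho to a large group and para to the 1,3-benzothiazol-2-yl group. For the measured compounds named here, no measured pair shows this change on its own. The step of a 2.0-fold higher number from compound 1 to compound 4 (0.30 log units; within the scatter) is expected to be a modest rise in solubility, possibly not beyond the scatter. Compound 4 is estimated at 200 nM, within a range of 80 nM to 600 nM.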

Compound 4, solubility: 580 nM
The estimate for compound 4 lay 2.9-fold (0.46 log units) below the measured number, and the stated range covers the measured number.
By their numbers in this assay, from the lowest: compound 1; then compounds 2, 4 and 3 (each within the scatter of the next, the first and the last beyond it).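

Hydrogen in place of chloro on an aromatic carbon, ortho to a large group and para to a 1,3-benzothiazol-2-yl group, gives a 5.8-fold higher number from compound 1 to compound 4 (0.76 log units; beyond the scatter) in this assay. For the compounds shown here, this is the first pair here that differs in one place, so the chloro at this position can now be judged on its own, and its removal moves the number beyond the scatter. Nothing measured here accounts for the size of this step.

Going by these compounds, whether fluoro, methoxy or an amine on this carbon would give a number like that of compound 4 remains open. So does whether the step would repeat on another core.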